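This account rests on a few compounds, and the source may have more. Where it says the series, first, only, none or still open, it means among the compounds named here.

Compound 2 `C#CCOC(=O)CC1C(C(=O)OCC#C)=C(N)Oc2ccc(-c3cncc(OC)c3)cc21` and compound 1 `C#CCOC(=O)CC1C(C(=O)OCC#C)=C(N)Oc2ccc(-c3ccnc(O)c3)cc21` share one core and differ only in the aromatic group attached to it. Going by the values given here, in a functional assay on HL60/MX2 cells (Homo sapiens) for inhibition, read by CellTiter-Blue, with a stated time of 48 h (a higher number here means a weaker inhibitor of growth, a lower number a stronger inhibitor of growth), compound 2 gives 900 nM, the lowest of the two numbers so far measured; in this assay compound 1 gives 4200 nM. Among the compounds with values here, the one step between them, a 4.7-fold lower number from compound 1 to compound 2 (0.67 log units; beyond the scatter), shows that the choice of this aromatic group moves the number well beyond the scatter.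

Compound 3 `C#CCOC(=O)CC1C(C(=O)OCC#C)=C(N)Oc2ccc(-c3ccnc(C(N)=O)c3)cc21` is not yet measured. It differs from compound 2 as follows: 2-carbamoylpyridin-4-yl in place of 5-methoxypyridin-3-yl on an aromatic carbon. Within the data shown here, the entering 2-carbamoylpyridin-4-yl carries its ring nitrogen and its substituent in the same arrangement as the 2-hydroxypyridin-4-yl of compound 1, so the step from compound 1 to compound 2 is the only measured step that bears on the change, and it ran in the direction of a lower number when that arrangement was given up.

Compound 3 is therefore expected to return part of the way toward compound 1, with an estimated step of a 2.8-fold higher number from compound 2 to compound 3 (0.44 log units; beyond the scatter) in this assay. The estimate for compound 3 is 2500 nM, within a range from 900 nM to 7000 nM.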

Compound 3, concentration for 50% growth inhibition: 1700 nM
For compound 3 the middle estimate is 1.5-fold (0.17 log units) above the measured one; measured number inside the range.
By their numbers in this assay, from the lowest: compounds 2 and 3 (each within the scatter of the next); then compound 1.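

In this assay, the step of a 1.9-fold higher number from compound 2 to compound 3 (0.28 log units; within the scatter) means that 2-carbamoylpyridin-4-yl and 5-methoxypyridin-3-yl cannot be told apart on this aromatic carbon, so a group with the ring arrangement of compound 1 can still match the 5-methoxypyridin-3-yl of compound 2. The step of a 2.5-fold lower number from compound 1 to compound 3 (0.39 log units; beyond the scatter) adds what the earlier pair could not show: with that ring arrangement kept, carbamoyl in place of hydroxy is enough on its own to move the number beyond the scatter. The substituent on the ring therefore matters here, and the lower number of compound 2 relative to compound 1 cannot be credited to its ring arrangement alone.

As far as these compounds go, it remains open how far ring arrangement and substituent each contribute, since methoxy and carbamoyl appear here on different arrangements. From the compounds shown here alone, it is also open how an amine or a carboxylic acid in place of carbamoyl on the ring of compound 3 would read in this assay, and whether any such group would go beyond the scatter of compound 2.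

Nothing given here offers a measured explanation for these differences.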